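Trading Methoxy for Chlorine on the Least Stable Compound

A few compounds are considered here, and "the series" means these few. Any claim that something is new, unique, unknown or untested is made for them only; others in the source may bear on it.

So far, three compounds have been measured in an ADME assay on microsomes from liver (Rattus norvegicus) for metabolic stability, read by LC-MS, with a stated time of 1 h, at 37 degrees C, tested at 4 uM; on this read-out lower numbers stand for a less stable compound and higher numbers for a more stable compound. Compound 1 (`CN(C)C(=O)c1cc(-c2cccc(COc3ccc4c(=O)n(C5CCCC5)sc4c3)c2)ccc1Cl`) gives 92%, and compound 3 (`CC(C)CCn1sc2cc(OCc3cccc(-c4ccc(Cl)c(C(=O)O)c4)c3)ccc2c1=O`) gives 92%. Compound 2 (`COc1ccc(C(=O)O)cc1-c1cccc(COc2ccc3c(c2)CN(C2CCCC2)C3=O)c1`) gives 30%, the lowest of the three numbers, and its gap to each of the other two lies beyond the usual scatter of repeated measurements.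

The next compound to be tested is compound 4 (`O=C(O)c1ccc(-c2cccc(COc3ccc4c(c3)CN(C3CCCC3)C4=O)c2)c(Cl)c1`), which keeps the core of compound 2. Among the measured compounds shown here, the one structural change is 4-carboxy-2-chlorophenyl in place of 5-carboxy-2-methoxyphenyl on an aromatic carbon. In plain words, 4-carboxy-2-chlorophenyl takes the place of 5-carboxy-2-methoxyphenyl on an aromatic carbon.

For the measured compounds named here, no measured pair of compounds isolates this change, so any forecast rests on indirect evidence. Compound 1 and compound 3 both carry a chlorine and no methoxy group, and both stand well above compound 2 in this assay. However, their core differs from that of compound 2, so neither comparison is like for like, and only part of that gap is expected to carry over. The expected change is a number 25 percentage points higher from compound 2 to compound 4 (beyond the scatter), a moderate rise beyond the scatter. For compound 4 the estimated value is 55%, with an expected range from 32% to 82%.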

Compound 4, percent of the compound remaining: 3%
Estimate against measurement, compound 4: 52 percentage points above, and the stated range ends above it.
By their numbers in this assay, from the lowest: compound 4; then compound 2; then compounds 1 and 3 (each within the scatter of the next).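

In this assay, putting 4-carboxy-2-chlorophenyl in place of 5-carboxy-2-methoxyphenyl gives a number 27 percentage points lower from compound 2 to compound 4 (beyond the scatter) on the shared core, so the number moves down rather than up, and compound 2 is no longer the lowest of the set. Among the compounds shown here, this is the first direct reading of a change at this position, and it shows that a ring carrying chlorine and no methoxy group does not bring a high number on this core, so the high numbers of compound 1 and compound 3, which sit on a different core, do not transfer here. Nothing in the data shown explains why the number falls.

The swap also changes two things at once, since the methoxy group gives way to chlorine and the carboxylic acid sits at a different place on the ring, and these two compounds cannot separate those effects. From the compounds shown here alone, it remains open whether a fluorine in place of the chlorine, or an amine or a primary amide in place of the carboxylic acid, would shift the number on this core, and whether any such group could lift it well clear of the low values seen for these two compounds.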